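A few compounds are considered here, and "the series" means these few. Any claim that something is new, unique, unknown or untested is made for them only; others in the source may bear on it.

Compound 1 `Cc1ccc(C(=O)c2ccn(-c3ccc4c(c3)B(O)OC4)c2)cc1`: in an ADME assay on L929 cells (Mus musculus) for cytotoxicity, read by resazurin assay, with a stated time of 72 h (a higher number here means a weaker inhibitor, a lower number a stronger inhibitor), compound 1 gives > 10 ug/mL, which is a limit of the assay rather than a number.
Compound 2 `CCCC(=O)c1ccn(-c2ccc3c(c2)B(O)OC3)c1`: in this assay compound 2 gives > 10 ug/mL, again a limit and not a number.

Within the data shown here, compound 2 therefore stands only at a limit in this assay, and the one neighbouring value sits at the same place (the limit of > 10 ug/mL in this assay, at which 2 of the 2 values shown sit). Among the measured compounds shown here, the single step in hand, a step that the two limits leave unreadable from compound 1 to compound 2, is left unreadable by the two limits, so it gives no measure of how far a change on the carbonyl carbon can move the read-out. Compound 3 `O=C(c1ccn(-c2ccc3c(c2)B(O)OC3)c1)c1cccs1` differs from compound 2 by thiophen-2-yl in place of propyl on a carbonyl carbon. For the measured compounds named here, no measured step bears on this particular exchange, and the only related step is unreadable. The expectation for compound 3 is accordingly a step that the limit leaves unreadable from compound 2 to compound 3 that does not go beyond the scatter, with compound 3 most likely also reported as a limit. Compound 3 is estimated at 15 ug/mL, with a range from 5 ug/mL to 50 ug/mL.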

Compound 3, half-maximal inhibitory concentration: > 10 ug/mL
Compound 3: no number, only a limit (the forecaster's own chance of this, stated with the estimate: 80%); the middle value lies beyond the limit too.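

Compound 3 sits at a limit, as do compound 1 and compound 2, so no step among these three compounds can be read: the limit of > 10 ug/mL in this assay, at which 3 of the 3 values shown sit.

The compounds shown leave open whether exchanging the group on the carbonyl carbon moves the read-out at all, and by how much.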